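The source may report more compounds than this note shows. Statements on the series, on what has been measured and on what is new or still open speak of the compounds shown alone.

For the measured compounds named here, in a functional assay on HGC-27 cells (Homo sapiens) for inhibition, read by MTT assay, with a stated time of 72 h (on this read-out lower numbers stand for stronger inhibition and higher numbers for weaker inhibition), compound 1 `O=C(NCc1ccc(NC(=O)c2cc(-c3ccccc3)ccc2N2CCCC2)cc1)OCc1cccnc1` gives 4340 nM and compound 2 `O=C(NCc1ccc(NC(=O)c2cc(Cl)ccc2N2CCCC2)cc1)OCc1cccnc1` gives 750 nM, the lower of the two numbers so far. The next compound is compound 3 `O=C(NCc1ccc(NC(=O)c2cc(Br)ccc2N2CCCC2)cc1)OCc1cccnc1`, with the change (bromo in place of chloro on an aromatic carbon). Bromo takes the place of chloro on an aromatic carbon, para to a pyrrolidin-1-yl group, and the rest of the structure stays the same. Going by the values given here, only one measured step bears on this place: a 5.8-fold lower number from compound 1 to compound 2 (0.76 log units; beyond the scatter), with chloro in place of phenyl. That step took a ring away, whereas no ring leaves or enters in the present change, so it gives only a loose guide and its size is not expected to recur. Among the compounds with values here, no measured pair yet compares bromo with chloro, and the data give no basis for a direction. No step beyond the scatter is therefore expected in this assay, and the estimate stays close to compound 2. The expected change is a 1.1-fold lower number from compound 2 to compound 3 (0.03 log units; within the scatter). Compound 3 is estimated at 700 nM, with an expected range of 300 nM to 1600 nM.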

Compound 3, half-maximal inhibitory concentration: 640 nM
Compound 3: middle estimate off by 1.1-fold (0.04 log units), on the high side; low and high end bracket the measured number.
By their numbers in this assay, from the lowest: compounds 3 and 2 (each within the scatter of the next); then compound 1.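

In this assay, the place para to a pyrrolidin-1-yl group now carries two different halogens, and exchanging chloro for bromo gives a 1.2-fold lower number from compound 2 to compound 3 (0.07 log units; within the scatter) with no separation of compound 2 and compound 3 on this read-out. The replacement of phenyl by bromo gives a 6.8-fold lower number from compound 1 to compound 3 (0.83 log units; beyond the scatter) and runs the same way as a 5.8-fold lower number from compound 1 to compound 2 (0.76 log units; beyond the scatter), so the difference from the phenyl compound now holds for two replacements rather than one. No measurement on these compounds accounts for either step.

With only phenyl, chloro and bromo at this place, the series does not show whether the lower numbers call for a halogen at all or only for the absence of the phenyl ring. Going by these compounds, it remains open whether hydrogen, fluoro, methyl or methoxy would read with compound 2 and compound 3 or with compound 1, and how an amine or a carboxylic acid at the same place would read.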